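Series notes: pendant aryl replacement on compound 3

A few compounds are considered here, and "the series" means these few. Any claim that something is new, unique, unknown or untested is made for them only; others in the source may bear on it.

Three compounds of the shared core have numbers in a functional assay on Malme-3M cells (Homo sapiens) for inhibition, read by sulforhodamine B assay, with a stated time of 48 h; a lower number here means a stronger inhibitor of growth, a higher number a weaker inhibitor of growth. Compound 1 `COc1cc(C)cc(-c2c(-c3ccnc(-c4ccc(C(C)=O)cc4)c3)cnn2CC#N)c1` gives 5820 nM in this assay. Compound 2 `COc1cc(C)cc(-c2nn(CC#N)cc2-c2ccc(-c3cccc(C(C)=O)c3)nc2)c1` gives 3760 nM in this assay. Compound 3 `Cc1cc(O)cc(-c2nn(CC#N)cc2-c2ccnc(-c3ccc(Oc4ccccc4)cc3)c2)c1` gives 1810 nM in this assay, the lowest of the three numbers; its step to compound 2 and its larger step to compound 1 are both beyond the scatter, so compound 3 is the strongest growth inhibitor of the three. No pair among these differs in only one place, so no single-change step is available to guide the next one.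

Compound 4 `Cc1cc(O)cc(-c2nn(CC#N)cc2-c2ccnc(-c3ccc(N(C)C)cc3)c2)c1` is not yet measured in this assay. It differs from compound 3 by dimethylamino in place of phenoxy on an aromatic carbon, a smaller group entering with no ring. Within the data shown here, the data give no step of this kind, so the expectation is a small step, likely toward a higher number, possibly within the scatter. The expected step from compound 3 to compound 4 in this assay is a 1.4-fold higher number from compound 3 to compound 4 (0.14 log units; within the scatter). Compound 4 is estimated to give about 2500 nM in this assay, in a range from 900 nM to 7000 nM.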

Compound 4, concentration for 50% growth inhibition: 4560 nM
Compound 4: middle estimate off by 1.8-fold (0.26 log units), on the low side; the measured number falls inside the stated range.
By their numbers in this assay, from the lowest: compound 3; then compounds 2, 4 and 1 (each within the scatter of the next).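

Among these compounds, this is the first single-change step: in this assay, dimethylamino in place of phenoxy on an aromatic carbon para to a large group gives a 2.5-fold higher number from compound 3 to compound 4 (0.40 log units; beyond the scatter). The position is therefore not indifferent to the group it carries, and here the smaller group without a ring goes with weaker growth inhibition. No measurement at hand accounts for this step.

This single step cannot separate the loss of the aromatic ring from the change in overall size or the change from an oxygen link to a nitrogen link. Methoxy, anilino or benzyloxy on the same carbon would help pull these apart, and whether any group there gives a lower number than phenoxy remains open.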